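This account rests on a few compounds, and the source may have more. Where it says the series, first, only, none or still open, it means among the compounds named here.

Within the data shown here, compound 2 `CCCC(C)Oc1cccc2ccc(N)nc12` holds the lowest number of the two measured so far in an assay on cells with melanin-concentrating hormone receptor 1 (Homo sapiens) as the target, read by radioligand binding; a higher number here means a weaker inhibitor, a lower number a stronger inhibitor; compound 2 gives 105 nM, whereas compound 1 `COCC(C)Oc1cccc2ccc(N)nc12` gives 606 nM. Among the measured compounds shown here, the one step in hand, a 5.8-fold lower number from compound 1 to compound 2 (0.76 log units; beyond the scatter), is the closest guide. Compound 3 `CCOCC(C)Oc1cccc2ccc(N)nc12` carries ethoxy in place of ethyl on a saturated chain carbon, two bonds along the chain from an oxygen on an aromatic ring, which puts an oxygen back at the chain position that compound 1 also holds. Because a 5.8-fold lower number from compound 1 to compound 2 (0.76 log units; beyond the scatter) went with removal of that oxygen, the expected step of a 2.9-fold higher number from compound 2 to compound 3 (0.46 log units; beyond the scatter) is a rise in this assay, smaller than the earlier step since the ethyl carbons stay. Compound 3 is expected near 300 nM, within 120 nM to 750 nM.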

Compound 3, half-maximal inhibitory concentration: 1070 nM
For compound 3 the middle estimate is 3.6-fold (0.55 log units) below the measured one, outside the stated range (above it).
By their numbers in this assay, from the lowest: compound 2; then compounds 1 and 3 (each within the scatter of the next).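

In this assay, the change at this saturated chain carbon from ethyl to ethoxy is a large one (a 10-fold higher number from compound 2 to compound 3 (1.01 log units; beyond the scatter)), so the gain in compound 2 does not survive once an oxygen returns to the chain. Lengthening methoxy to ethoxy makes no difference beyond the scatter (a 1.8-fold higher number from compound 1 to compound 3 (0.25 log units; within the scatter)), so among these three compounds the higher numbers go with a chain oxygen, whichever of the two ethers is present. Nothing on hand explains this. Going by these compounds, whether a longer chain such as butyl lowers the number further remains open. So does whether an amine or a hydroxyl in the chain tracks with the ethers or with compound 2.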